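From an Indole Amide to a Phenylethenyl Amide

The compounds below may be only part of what the source reports. "The series", "measured", "known", "first", "only" and "open" are said of these compounds alone.

Compound 1 `CCCCCCCCCCCCCCCCCCNC(=O)[C@@H](NC(=O)c1nccc2ccccc12)[C@@H](C)O` and compound 2 `CCCCCCCCCCCCCCCCCCNC(=O)[C@@H](NC(=O)c1cc2ccccc2n1C)[C@@H](C)O` share a long-chain amide core and differ only in the aryl group on the carbonyl carbon. In a functional assay on HepG2 cells (Homo sapiens) for cytotoxicity, read by MTT assay, with a stated time of 48 h (on this read-out higher numbers stand for weaker inhibition and lower numbers for stronger inhibition), compound 1 gives 96900 nM. For compound 2 the same assay reports only a limit, > 200000 nM, so no number is known for it. The step of an at least 2.0-fold higher number from compound 1 to compound 2 (0.31 log units; beyond the scatter) is therefore bounded on one side only, and the reason is the limit of > 200000 nM in this assay, at which 1 of the 2 values shown sits. Compound 2 thus stands at the weak edge of what the assay can report, alongside a compound 1 that is itself weak.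

Compound 3 `CCCCCCCCCCCCCCCCCCNC(=O)[C@@H](NC(=O)/C=C/c1ccccc1)[C@@H](C)O` is reached from compound 2 by the change (2-phenylethenyl in place of 1-methyl-1H-indol-2-yl on a carbonyl carbon). For the measured compounds named here, the only measured step bears on this change indirectly: it shows that swapping one aryl group for another at this carbonyl carbon moved the number by an at least 2.0-fold higher number from compound 1 to compound 2 (0.31 log units; beyond the scatter), and in the direction of weaker inhibition. With both known values this weak, the expected step of an at least 1.3-fold lower number from compound 2 to compound 3 (0.12 log units; that floor lies within the scatter) in this assay is small and may not lift compound 3 off the limit. Compound 3 is estimated at 150000 nM, expected between 60000 nM and 300000 nM.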

Compound 3, half-maximal inhibitory concentration: 128000 nM
Estimate against measurement, compound 3: 1.2-fold (0.07 log units) above; the measured number falls inside the stated range.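

Compound 3 gives this carbonyl carbon, whose other neighbour is an amide-type nitrogen, a comparison with a number at both ends. In this assay the step of a 1.3-fold higher number from compound 1 to compound 3 (0.12 log units; within the scatter) cannot separate 2-phenylethenyl from isoquinolin-1-yl, so these two groups, which differ in what is counted on them, read alike at this place. Compound 2 has only a limit, so the step of an at least 1.5-fold lower number from compound 2 to compound 3 (0.19 log units; that floor lies within the scatter) is bounded on one side and does not show that 2-phenylethenyl differs from 1-methyl-1H-indol-2-yl: the limit of > 200000 nM in this assay, at which 1 of the 3 values shown sits.

Open, from the compounds shown here alone, is whether the double bond of 2-phenylethenyl matters, which a saturated 2-phenylethyl group on the same carbonyl carbon would test, and whether an amine or a carboxylic acid on its six-membered ring would move the number at all. Also open, going by these compounds, is whether a shorter chain in place of the long chain of the shared core would change the read-out more than any exchange at the carbonyl carbon has done so far.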